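This account rests on a few compounds, and the source may have more. Where it says the series, first, only, none or still open, it means among the compounds named here.

Measured so far in an assay on CHO cells for antagonist activity at transient receptor potential cation channel subfamily V member 1 (Homo sapiens), read by FLIPR; on this read-out higher numbers stand for weaker inhibition and lower numbers for stronger inhibition:
compound 1 `CC(C(=O)NCc1ccc(C(F)(F)F)nc1-c1ccccc1F)c1ccc(NS(C)(=O)=O)c(F)c1`: 63.3 nM
compound 2 `CC(C(=O)NCc1ccc(C(F)(F)F)nc1-c1ccc(Cl)cc1)c1ccc(NS(C)(=O)=O)c(F)c1`: 0.7 nM
compound 3 `Cc1cc(-c2nc(C(F)(F)F)ccc2CNC(=O)C(C)c2ccc(NS(C)(=O)=O)c(F)c2)ccc1F`: 0.4 nM

Compound 3 gives the lowest of the three numbers, but its nearest neighbour is close: the step of a 1.8-fold lower number from compound 2 to compound 3 (0.24 log units; within the scatter) stays within the scatter, so compound 2 and compound 3 cannot be told apart on this read-out. The far end is compound 1, and the step of a 160-fold lower number from compound 1 to compound 3 (2.20 log units; beyond the scatter) is large, as is a 90-fold lower number from compound 1 to compound 2 (1.96 log units; beyond the scatter).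

Compound 4 `COc1ccc(-c2nc(C(F)(F)F)ccc2CNC(=O)C(C)c2ccc(NS(C)(=O)=O)c(F)c2)cc1OC` differs from compound 3 in one place: 3,4-dimethoxyphenyl in place of 4-fluoro-3-methylphenyl on an aromatic carbon. Two of the measured steps bear on this position. Among the compounds with values here, both large steps leave the 2-fluorophenyl, and the one step between two groups that each carry the para position, from compound 2 to compound 3, is within the scatter. Within the data shown here, no measured step puts a methoxy group at this position, so the data give no direct guide to two acceptors here. The expectation for compound 4 is therefore a small rise, a 7.5-fold higher number from compound 3 to compound 4 (0.88 log units; beyond the scatter), likely near the edge of the scatter. The estimate for compound 4 is 3 nM, with a range from 0.5 nM to 20 nM.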

Compound 4, inhibition constant: 25.6 nM
The estimate for compound 4 lay 8.5-fold (0.93 log units) below the measured number; the measured number lies above the stated range.
By their numbers in this assay, from the lowest: compounds 3 and 2 (each within the scatter of the next); then compound 4; then compound 1.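

In this assay, within the data shown here, the 2-fluorophenyl of compound 1 was the only group at this position with a high number, and 3,4-dimethoxyphenyl now also gives a large rise (a 64-fold higher number from compound 3 to compound 4 (1.81 log units; beyond the scatter)) and (a 37-fold higher number from compound 2 to compound 4 (1.56 log units; beyond the scatter)). The low numbers of 4-chlorophenyl and 4-fluoro-3-methylphenyl are therefore not shared by every substituted phenyl here, although the dimethoxy group still sits modestly lower than 2-fluorophenyl (a 2.5-fold lower number from compound 1 to compound 4 (0.39 log units; beyond the scatter)). Compared with 4-fluoro-3-methylphenyl, it brings hydrogen-bond acceptors and more heavy atoms, but no available measurement shows whether either accounts for the rise.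

Going by these compounds, whether one methoxy group alone, as in 4-methoxyphenyl or 3-methoxyphenyl, keeps the low numbers of compound 2 and compound 3 remains open. Also open, on these data alone, is how a phenyl carrying an amine or a carboxylic acid would read at this position.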